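Replacing a Lactam with an Aminothiazole: Stability Expectation

A few compounds are considered here, and "the series" means these few. Any claim that something is new, unique, unknown or untested is made for them only; others in the source may bear on it.

In an ADME assay on microsomes from liver (Homo sapiens) for metabolic stability (on this read-out lower numbers stand for a shorter-lived compound and higher numbers for a longer-lived compound), compound 2 `CC(C)C(c1ccc(-c2ccc3cccc(F)c3c2)[nH]c1=O)N1CCCCC1=O` gives 0.183 h, the lowest of the two numbers shown, with compound 1 `CC(C)C(c1nnc[nH]1)c1ccc(-c2ccc3cccc(F)c3c2)[nH]c1=O` as its nearest neighbour, where compound 1 gives 0.905 h. Compound 3 `CC(C)C(Cc1nnn[nH]1)c1ccc(-c2ccc3cccc(F)c3c2)[nH]c1=O` stands at a limit of this assay, since compound 3 gives > 3 h (the limit of > 3 h in this assay, at which 1 of the 3 values shown sits).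

The step from compound 2 to compound 4 `CC(C)C(c1cnc(N)s1)c1ccc(-c2ccc3cccc(F)c3c2)[nH]c1=O` consists of 2-amino-1,3-thiazol-5-yl in place of 2-oxopiperidin-1-yl on a saturated chain carbon bound to an aromatic carbon and a saturated chain carbon. Two of the measured steps speak to it, as both exchange a small aromatic heterocycle for the 2-oxopiperidin-1-yl at the same place: a 4.9-fold lower number from compound 1 to compound 2 (0.69 log units; beyond the scatter), and an at least 16-fold higher number from compound 2 to compound 3 (1.21 log units; beyond the scatter). Both times the 2-oxopiperidin-1-yl compound was the shorter-lived one, and each step lay beyond the scatter. The 2-amino-1,3-thiazol-5-yl is a five-membered aromatic ring with two hetero atoms, which puts compound 4 closer in kind to compound 1 than to compound 3, so a rise of modest rather than large size is expected, in the direction of a longer half-life.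

Compound 4 is therefore expected to give 0.7 h in this assay, within 0.25 h to 2 h, an estimated 3.8-fold higher number from compound 2 to compound 4 (0.58 log units; beyond the scatter).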

Compound 4, half-life: 0.178 h
For compound 4 the middle estimate is 3.9-fold (0.59 log units) above the measured one; measured number below the stated range.
By their numbers in this assay, from the lowest: compounds 4 and 2 (each within the scatter of the next); then compound 1. At a limit, above all of these: compound 3.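

At this saturated chain carbon, 2-amino-1,3-thiazol-5-yl and 2-oxopiperidin-1-yl give no separable half-life in this assay, with a 1.0-fold lower number from compound 2 to compound 4 (0.01 log units; within the scatter), so among the compounds shown a five-membered aromatic ring in this place does not by itself go with a longer-lived compound. The identity of the ring counts here, as the 4H-1,2,4-triazol-3-yl of compound 1 and the 2-amino-1,3-thiazol-5-yl stand apart, with a 5.1-fold lower number from compound 1 to compound 4 (0.71 log units; beyond the scatter). The gap to the (1H-tetrazol-5-yl)methyl group is larger, with an at least 16-fold lower number from compound 3 to compound 4 (1.22 log units; beyond the scatter), and this step rests on compound 3, which stands at a limit of this assay: the limit of > 3 h in this assay, at which 1 of the 4 values shown sits.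

On these data alone, what remains open is whether the short half-life of compound 4 belongs to the amine or to the thiazole ring itself, which a plain 1,3-thiazol-5-yl, or a methyl or an acetamide in place of the amine, could separate. Also open, as far as these compounds go, is how far the half-life of compound 3 really reaches, and whether a (1H-1,2,4-triazol-3-yl)methyl group or a carboxylic acid on the same chain carbon would stand nearer to compound 3 or to compound 1.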